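From Aminopiperidine to Hydroxypiperidine: an Antiproliferative Estimate

The source may hold more compounds than are shown below. What is called first, only, known or untested is meant among the compounds shown, and "the series" means these compounds.

Compound 1, `COc1cc[nH]c1/C=C1\C(=O)Nc2ccc([N+](=O)[O-])c(N[C@H]3CC[C@H](O)CC3)c21`: 8550 nM
Compound 2, `COc1cc[nH]c1/C=C1\C(=O)Nc2ccc([N+](=O)[O-])c(N3CCC(N)CC3)c21`: a limit of the assay, < 10 nM

In a functional assay on MDA-MB-435 cells (Homo sapiens) for antiproliferative activity, read by MTT assay, with a stated time of 5 days (on this read-out higher numbers stand for weaker inhibition and lower numbers for stronger inhibition), compound 1 gives 8550 nM. For compound 2 the result is only a limit of the assay, < 10 nM, so its true number is not known; it stands at the favourable edge of what was measured. Among the measured compounds shown here, the one measured step, an at least 850-fold lower number from compound 1 to compound 2 (2.93 log units; beyond the scatter), is large, and it rests on the limit of < 10 nM in this assay, at which 1 of the 2 values shown sits, rather than on a measured number for compound 2.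

Compound 3, `COc1cc[nH]c1/C=C1\C(=O)Nc2ccc([N+](=O)[O-])c(N3CCCC(O)C3)c21`, is not yet measured. It differs from compound 2 by 3-hydroxypiperidin-1-yl in place of 4-aminopiperidin-1-yl on an aromatic carbon. Compound 3 keeps the piperidinyl attachment of compound 2 while exchanging the amino group for a hydroxyl, and compound 1, which carries a hydroxyl on a ring with the earlier attachment, sits far weaker. For the measured compounds named here, only the step from compound 1 to compound 2 bears on this change, and it mixes two alterations at once, so its size cannot be cleanly assigned to either. A move toward weaker inhibition is expected, an at least 20-fold higher number from compound 2 to compound 3 (1.30 log units; beyond the scatter), though with wide uncertainty since compound 2 is only a limit. Compound 3 is estimated at 200 nM, within 20 nM to 2000 nM.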

Compound 3, half-maximal inhibitory concentration: 250 nM
Beside the measured number, compound 3's estimate is 1.3-fold (0.10 log units) below it; measured number inside the range.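

In this assay, the new result shows that a hydroxyl-bearing piperidine on this aromatic carbon, ortho to a nitro group, retains real activity, yet replacing 4-aminopiperidin-1-yl with 3-hydroxypiperidin-1-yl still gives an at least 25-fold higher number from compound 2 to compound 3 (1.39 log units; beyond the scatter). Compounds 1 and 3 both carry a hydroxyl, but 3-hydroxypiperidin-1-yl in place of (4-hydroxycyclohexyl)amino gives a 34-fold lower number from compound 1 to compound 3 (1.53 log units; beyond the scatter), so the presence of a hydroxyl alone does not set the activity here, and the rest of the group matters as well. The step from compound 2 gives only a minimum size, not a measured one, because it rests on a limit for compound 2: the limit of < 10 nM in this assay, at which 1 of the 3 values shown sits.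

The compounds shown leave open whether the loss from compound 2 to compound 3 comes from exchanging the amino group for a hydroxyl or from the different place of that group on the piperidine ring, a question that 4-hydroxypiperidin-1-yl or 3-aminopiperidin-1-yl would help to separate. They also leave open how a carboxylic acid or a longer chain on the piperidine ring would behave at this carbon.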